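Cytotoxicity notes on the shared core: toward compound 4

This account rests on a few compounds, and the source may have more. Where it says the series, first, only, none or still open, it means among the compounds named here.

Compound 1 `COc1ccc(NC(=O)NC[C@H]2O[C@H](n3cc(C)c(=O)[nH]c3=O)C[C@@H]2O)cc1` is the reference point of this set. In an ADME assay on MRC5 cells (Homo sapiens) for cytotoxicity (a higher number here means that more compound is tolerated, a lower number that less compound is tolerated), compound 1 gives > 50000 nM, which is a limit of the assay rather than a number. Compound 2 `Cc1cn([C@@H]2C[C@H](O)[C@@H](CNC(=O)Nc3ccc(OC4CCOCC4)cc3)O2)c(=O)[nH]c1=O` likewise reaches only a limit, > 50000 nM. Compound 3 `Cc1ccc2nc(-c3ccc(NC(=O)NC[C@H]4O[C@H](n5cc(C)c(=O)[nH]c5=O)C[C@@H]4O)cc3)sc2c1` also gives a limit, > 50000 nM. In short, (the limit of > 50000 nM in this assay, at which 3 of the 3 values shown sit). The steps a step that the two limits leave unreadable from compound 1 to compound 2, a step that the two limits leave unreadable from compound 1 to compound 3 and a step that the two limits leave unreadable from compound 2 to compound 3 therefore carry no readable size or direction. Compound 4 `COc1ccc(COc2ccc(NC(=O)NC[C@H]3O[C@H](n4cc(C)c(=O)[nH]c4=O)C[C@@H]3O)cc2)cc1` differs from compound 1 by 4-methoxyphenyl in place of hydrogen on a saturated chain carbon bound to an oxygen on an aromatic ring. Within the data shown here, no measured step bears on this change beyond the shared limit, so no direction can be read from the data; for compound 4 the step that the limit leaves unreadable from compound 1 to compound 4 is expected to be none beyond the scatter. Compound 4 is estimated at 60000 nM, with a range of 25000 nM to 150000 nM.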

Compound 4, half-maximal cytotoxic concentration: > 50000 nM
Compound 4 ended at the assay's limit; the forecaster's own chance of this, stated with the estimate: 80%; the middle value does not contradict the limit.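

Among these compounds, compound 4 sits at the same limit as compounds 1, 2 and 3, so no step from any of them to compound 4 can be read: the limit of > 50000 nM in this assay, at which 4 of the 4 values shown sit. Going by these compounds, whether these four compounds differ at all in this assay remains open.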